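Removing the propyl from the amide nitrogen of compound 2

The source may report more compounds than this note shows. Statements on the series, on what has been measured and on what is new or still open speak of the compounds shown alone.

For the measured compounds named here, compound 2 `CCCN1CC(=O)N(CCC)c2ncn(Cc3ccccc3)c2C1=O` is the only compound of this set with a number in an assay for binding affinity to adenosine receptor A1 (Rattus norvegicus), read by radioligand binding; on this read-out higher numbers stand for weaker inhibition and lower numbers for stronger inhibition; in this assay compound 2 gives 11000 nM. Compound 1 `CCCN1CC(=O)N(CCC)c2ncn(C)c2C1=O` reaches only a limit, > 250000 nM. Compound 3 `CCN1CC(=O)N(CC)c2[nH]cnc2C1=O` likewise stops at a limit, > 250000 nM. Going by the values given here, the single measured step, an at least 22-fold lower number from compound 1 to compound 2 (1.35 log units; beyond the scatter), concerns the group on the aromatic nitrogen and not the amide nitrogen. Compound 4 `CCCN1C(=O)CNC(=O)c2c1ncn2Cc1ccccc1` differs from compound 2 by hydrogen in place of propyl on an amide-type nitrogen in a ring. Among the compounds with values here, no measured step touches that nitrogen, and the set is thin: the limit of > 250000 nM in this assay, at which 2 of the 3 values shown sit. One therefore expects compound 4 to bind more weakly, an estimated step of a 4.5-fold higher number from compound 2 to compound 4 (0.66 log units; beyond the scatter). The estimate for compound 4 is 50000 nM, with a range from 10000 nM to 250000 nM.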

Compound 4, inhibition constant: 32000 nM
Compound 4: the middle estimate sits 1.6-fold (0.19 log units) above what was measured; the measured number falls inside the stated range.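

The propyl on this amide-type nitrogen in the ring counts for something in this assay, though only modestly: its replacement by hydrogen gives a 2.9-fold higher number from compound 2 to compound 4 (0.46 log units; beyond the scatter). Compound 4 still gives a number and not a limit, so this propyl is not needed for a measurable reading, while limits remain common in the set: the limit of > 250000 nM in this assay, at which 2 of the 4 values shown sit.

As far as these compounds go, it stays open whether a methyl, a butyl or a chain carrying an amine on this nitrogen would give a lower number than propyl. Also open, from the compounds shown here alone, is what hydrogen would do on the ring atom that bears the other propyl group.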